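The compounds below may be only part of what the source reports. "The series", "measured", "known", "first", "only" and "open" are said of these compounds alone.

Compound 1 `O=C(/C=C/c1ccc2c(c1)B(O)OC2)c1ccc(O)cc1` and compound 2 `Cn1cccc1C(=O)/C=C/c1ccc2c(c1)B(O)OC2` share one core and differ only at the carbonyl carbon, where 1-methyl-1H-pyrrol-2-yl stands in place of 4-hydroxyphenyl. In an ADME assay on L929 cells (Mus musculus) for cytotoxicity, read by resazurin assay, with a stated time of 72 h (on this read-out higher numbers stand for weaker inhibition and lower numbers for stronger inhibition), compound 1 gives > 10 ug/mL, which is a limit of the assay and not a number. Compound 2 gives > 10 ug/mL in this assay, again a limit. The step that the two limits leave unreadable from compound 1 to compound 2 therefore has no readable size; all that is known is the limit of > 10 ug/mL in this assay, at which 2 of the 2 values shown sit. Compound 3 `CSc1ccc(C(=O)/C=C/c2ccc3c(c2)B(O)OC3)cc1` awaits measurement and carries methylsulfanyl in place of hydroxy on an aromatic carbon. Going by the values given here, no measured step bears on that change, and compound 1 itself stands only at a limit, so any expectation rests on the two limits alone. Compound 3 is expected to give 20 ug/mL in this assay, within 7 ug/mL to 60 ug/mL. The step that the limit leaves unreadable from compound 1 to compound 3 is accordingly expected to stay near the same limit.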

Compound 3, half-maximal inhibitory concentration: > 10 ug/mL
Compound 3: no number, only a limit; the forecaster's own chance of this, stated with the estimate: 70%; the middle value does not contradict the limit.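

In this assay compound 3 stands only at a limit of the assay, so no new step can be read from compound 1 to compound 3: the limit of > 10 ug/mL in this assay, at which 3 of the 3 values shown sit.

The compounds shown leave open where any of them would reach half-maximal inhibition, and whether methylsulfanyl in place of hydroxy on an aromatic carbon changes this read-out at all.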